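Cytotoxicity notes: aryl swap on the carbonyl carbon

A few compounds are considered here, and "the series" means these few. Any claim that something is new, unique, unknown or untested is made for them only; others in the source may bear on it.

Measured compounds
compound 1 `COc1ccc(-c2cc(/C=C/C(=O)c3ccc(N)cc3)[nH]n2)cc1`: -67%
compound 2 `COc1cc(-c2cc(/C=C/C(=O)c3ccc(N)cc3)[nH]n2)cc(OC)c1OC`: -67%

In a functional assay on KM12 cells (Homo sapiens) for cytotoxicity, read by sulforhodamine B assay, with a stated time of 48 h, tested at 10 uM (a higher number here means a weaker effect of the compound at the concentration tested, a lower number a stronger effect), compound 1 gives -67%. In this assay compound 2 gives -67%, level with compound 1 at the digits shown; the two values lie within the usual scatter of each other, so nothing distinguishes them here.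

Compound 3 `COc1cc(-c2cc(/C=C/C(=O)c3ccc(Cl)c(Cl)c3)[nH]n2)cc(OC)c1OC` is not yet measured. It differs from compound 2 in one place: 3,4-dichlorophenyl in place of 4-aminophenyl on a carbonyl carbon. Among the measured compounds shown here, no measured pair in this set shows a change of this kind, so the size of the step cannot be read from the data, and the aryl ring on the carbonyl carbon has not been varied in any measured compound.

The expectation for compound 3 is therefore weakly founded: the step of a number 9 percentage points higher from compound 2 to compound 3 (within the scatter) is estimated to be small, with no clear direction beyond the scatter. Compound 3 is expected to give about -58% in this assay, within a range from -90% to -10%.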

Compound 3, a percentage reported as activity, at one concentration (the size of the read-out at that concentration, not a potency): 19%
Beside the measured number, compound 3's estimate is 77 percentage points below it; the whole stated range lies below it.
By their numbers in this assay, from the lowest: compounds 1 and 2 (each within the scatter of the next); then compound 3.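

In this assay, putting 3,4-dichlorophenyl in place of 4-aminophenyl on a carbonyl carbon gives a number 86 percentage points higher from compound 2 to compound 3 (beyond the scatter), so the aryl ring at this position has a large influence on the read-out at the concentration tested. Compound 2 reads -67% and compound 3 reads 19%, so the sign of the read-out changes with this one swap, and the stronger effect stays with the 4-aminophenyl compound. Nothing at hand accounts for the step, and the amino group leaves as the two chlorines enter, so the two parts of the change cannot be told apart.

Open, from the compounds shown here alone, is which part of the change matters: a phenyl ring bearing one chlorine, a hydroxyl or a dimethylamino group at this position would begin to separate them. Going by these compounds, whether the step repeats on the core of compound 1 also remains open.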